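The compounds below may be only part of what the source reports. "The series", "measured", "known", "first", "only" and "open" are said of these compounds alone.

Compound 1 `COc1ccc2c(=O)c(/C=C/C(=O)Nc3cccc(Cl)c3)coc2c1`: 11900 nM
Compound 2 `COc1cccc(NC(=O)/C=C/c2coc3cc(OC)ccc3c2=O)c1`: 19200 nM

Within the data shown here, in a functional assay on HeLa cells (Homo sapiens) for inhibition, read by MTT assay, with a stated time of 48 h (a lower number here means a stronger inhibitor, a higher number a weaker inhibitor), compound 2 gives 19200 nM and so stands as the higher of the two numbers measured so far; its nearest neighbour is compound 1, which differs by a 1.6-fold higher number from compound 1 to compound 2 (0.21 log units; within the scatter). Compound 3 `COc1ccc(CNC(=O)/C=C/c2coc3cc(OC)ccc3c2=O)cc1` follows from compound 2 by 4-methoxybenzyl in place of 3-methoxyphenyl on an amide-type nitrogen. Among the measured compounds shown here, the only measured step, a 1.6-fold higher number from compound 1 to compound 2 (0.21 log units; within the scatter), concerns a substituent swap on the aromatic ring rather than the link to the amide nitrogen, so it bears on this change only loosely and argues for no clear direction. Compound 3 is therefore expected to shift by a 1.0-fold higher number from compound 2 to compound 3 (0.02 log units; within the scatter), giving an estimated 20000 nM in this assay, within a range of 8000 nM to 50000 nM.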

Compound 3, half-maximal inhibitory concentration: > 100000 nM
Compound 3: no number, only a limit (the forecaster's own chance of this, stated with the estimate: 15%); middle value at least 5.0-fold (0.69 log units) away from the limit.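

Compound 3 gives no number in this assay, only a limit: the limit of > 100000 nM in this assay, at which 1 of the 3 values shown sits. Even so, 4-methoxybenzyl on the amide-type nitrogen gives an at least 5.2-fold higher number from compound 2 to compound 3 (0.71 log units; beyond the scatter), and against the chloro-bearing partner it gives an at least 8.4-fold higher number from compound 1 to compound 3 (0.92 log units; beyond the scatter). This position therefore moves the result beyond the scatter, which the earlier swap of methoxy for chloro on the aromatic ring, a 1.6-fold higher number from compound 1 to compound 2 (0.21 log units; within the scatter), did not do.

The step alters both the link to the ring and the place of the methoxy group at once, and the compounds shown do not separate the two. A plain benzyl or 3-methoxybenzyl group on this nitrogen would tell them apart.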